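Swapping a silicon group for a chlorophenyl sulfonamide on the triazole

The compounds below may be only part of what the source reports. "The series", "measured", "known", "first", "only" and "open" are said of these compounds alone.

Measured compounds:
compound 1 `Cc1ccc(S(=O)(=O)NCc2cn(C[C@H](O)[C@H]3OC(=O)C(OCc4ccccc4)=C3OCc3ccccc3)nn2)cc1` gives 6400 nM
compound 2 `C[Si](C)(C)c1cn(C[C@H](O)[C@H]2OC(=O)C(OCc3ccccc3)=C2OCc2ccccc2)nn1` gives 12100 nM
compound 3 `CCCCCc1ccc(-c2cn(C/C=C3\OC(=O)C(OCc4ccccc4)=C3OCc3ccccc3)nn2)cc1` gives > 100000 nM

All three were tested in a functional assay on MCF7 cells (Homo sapiens) for antiproliferative activity, read by MTT assay, with a stated time of 72 h; a lower number here means a stronger inhibitor, a higher number a weaker inhibitor. Compound 3 gives only a limit of the assay, > 100000 nM, not a number. Among the two real numbers, compound 2 holds the higher one, with compound 1 nearest to it; the step of a 1.9-fold higher number from compound 1 to compound 2 (0.28 log units; within the scatter) stays within the scatter. Compound 4 `O=C1O[C@H]([C@@H](O)Cn2cc(CNS(=O)(=O)c3ccc(Cl)cc3)nn2)C(OCc2ccccc2)=C1OCc1ccccc1` is not yet measured. It differs from compound 2 as follows: a group of 12 heavy atoms (7 carbon, 1 nitrogen, 2 oxygen, 1 sulfur, 1 chlorine; one six-membered aromatic ring of carbon only) in place of a group of 4 heavy atoms (3 carbon, 1 silicon; no ring), on an aromatic carbon. Going by the values given here, the only measured step that bears on this change is the one from compound 1 to compound 2, where a group of 4 heavy atoms (3 carbon, 1 silicon; no ring) replaced a group of 12 heavy atoms with a six-membered aromatic ring, and the number moved by a 1.9-fold higher number from compound 1 to compound 2 (0.28 log units; within the scatter). The change to compound 4 runs the other way and adds a related sulfonamide, so a step of similar size back toward the number of compound 1 is expected, or none beyond the scatter. The expected step is a 1.9-fold lower number from compound 2 to compound 4 (0.27 log units; within the scatter). Compound 4 is therefore estimated at 6500 nM, between 3000 nM and 15000 nM.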

Compound 4, half-maximal inhibitory concentration: 4170 nM
The estimate for compound 4 lay 1.6-fold (0.19 log units) above the measured number; the range from low to high includes it.
By their numbers in this assay, from the lowest: compounds 4, 1 and 2 (each within the scatter of the next, the first and the last beyond it). At a limit, above all of these: compound 3.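

In this assay, going by these compounds alone, putting the (((4-chlorophenyl)sulfonyl)amino)methyl group in place of the silicon group on this aromatic carbon gives the first step at this position that clears the usual scatter, though only modestly: a 2.9-fold lower number from compound 2 to compound 4 (0.46 log units; beyond the scatter). Chloro in place of methyl on an aromatic carbon of the sulfonamide's ring cannot be told apart from no change, with a 1.5-fold lower number from compound 1 to compound 4 (0.19 log units; within the scatter), so these two sulfonamides read as equal in this assay. Nothing measured here explains why the larger group gives the lower number.

Going by these compounds, it remains open which part of the entering group matters, since a plain amine or an amide in place of the sulfonamide would separate the linker from the ring. A fluoro or a methoxy in place of the chloro would show whether that ring tolerates other groups.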